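Hydroxy for Hydrogen on the Chain of Compound 1

The source may report more compounds than this note shows. Statements on the series, on what has been measured and on what is new or still open speak of the compounds shown alone.

This account follows a small series of catechol-bearing chain compounds. Compound 1 `O=C(CCCCc1ccc(O)c(O)c1)CCc1ccc(O)c(O)c1` carries a carbonyl in the middle of its chain; in a functional assay, read by spectrophotometry, with a stated time of 10 min (on this read-out lower numbers stand for stronger inhibition and higher numbers for weaker inhibition), compound 1 gives 12700 nM. Compound 2 `Oc1ccc(CCCC[C@@H](O)CCc2ccc(O)c(O)c2)cc1O` has a hydroxy on its chain and no carbonyl, and in this assay compound 2 gives 11600 nM. Compound 3 `O=C(/C=C/CCc1ccc(O)c(O)c1)CCc1ccc(O)c(O)c1` has a carbonyl joined to a double bond, and in this assay compound 3 gives 16800 nM. Among these three numbers compound 1 stands second highest, and its gaps to compound 2 and to compound 3 are both within the usual scatter, so the three cannot be ordered.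

The next compound, compound 4 `O=C(CCc1ccc(O)c(O)c1)C[C@@H](O)CCc1ccc(O)c(O)c1`, is not yet measured. It differs from compound 1 in one place: hydroxy in place of hydrogen on a saturated chain carbon bound to two saturated chain carbons. The values of compound 1 and compound 2 show that a hydroxy-bearing chain and a carbonyl-bearing chain sit within the scatter of each other, which gives no ground for a step in either direction. The step is therefore expected to be a 1.1-fold lower number from compound 1 to compound 4 (0.02 log units; within the scatter), none beyond the scatter. In this assay compound 4 is estimated at 12000 nM, with a range from 6000 nM to 25000 nM.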

Compound 4, half-maximal inhibitory concentration: 19000 nM
The estimate for compound 4 lay 1.6-fold (0.20 log units) below the measured number, and the stated range covers the measured number.
By their numbers in this assay, from the lowest: compounds 2, 1, 3 and 4 (each within the scatter of the next).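

Among the compounds shown here, this is the first change that can be read at a single place: in this assay, hydroxy in place of hydrogen on a saturated chain carbon bound to two saturated chain carbons gives a 1.5-fold higher number from compound 1 to compound 4 (0.17 log units; within the scatter). The earlier compounds shown here offered no such single-place step, whereas this one shows that the chain of compound 1 can carry a hydroxy on this carbon, with its carbonyl still present, without a difference beyond the scatter. Nothing measured here bears on why the step is this size.

From the compounds shown here alone, because the step rests on one pair of compounds and one group, it remains open whether an amine, a methoxy group or a fluorine atom on the same saturated chain carbon would stay within the scatter or move beyond it. Going by these compounds, it is equally open whether hydroxy on other carbons of the chain, the opposite arrangement of hydroxy and hydrogen on this carbon, or a longer chain would give a step beyond the scatter in this assay.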